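The source may report more compounds than this note shows. Statements on the series, on what has been measured and on what is new or still open speak of the compounds shown alone.

Measured so far:
- compound 1 `COc1cccc(NC(=O)C2CCN(C/C=C/c3ccccc3)CC2)c1` gives 50500 nM
- compound 2 `O=C(Nc1ccccn1)C1CCN(C/C=C/c2ccccc2)CC1` gives 89300 nM

In a functional assay on A549 cells (Homo sapiens) for inhibition, read by MTT assay, with a stated time of 72 h (a higher number here means a weaker inhibitor, a lower number a stronger inhibitor), compound 2 stands at 89300 nM on the numbers shown. Compound 1 gives 50500 nM in the same test. The two values lie within the scatter of each other, so neither compound can be ranked ahead.

The next compound is compound 3 `O=C(NCc1ccccc1)C1CCN(C/C=C/c2ccccc2)CC1` and it has benzyl in place of pyridin-2-yl on an amide-type nitrogen. Going by the values given here, only one measured step bears on this place. It is a 1.8-fold higher number from compound 1 to compound 2 (0.25 log units; within the scatter) and it exchanged 3-methoxyphenyl for pyridin-2-yl on that same nitrogen. Among the compounds with values here, no measured compound carries benzyl, so this single step is thin support.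

Within the data shown here, with a 1.8-fold higher number from compound 1 to compound 2 (0.25 log units; within the scatter) as the only guide, no step beyond the scatter is expected in this assay for the new exchange. The estimated step is a 1.5-fold lower number from compound 2 to compound 3 (0.17 log units; within the scatter) and it is expected to stay within the scatter. For compound 3 the estimated value is 60000 nM with an expected range from 25000 nM to 150000 nM for this measurement.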

Compound 3, half-maximal inhibitory concentration: > 100000 nM
Compound 3 was reported as a limit (the forecaster's own chance of this, stated with the estimate: 12%); middle value at least 1.6-fold (0.22 log units) away from the limit.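

For compound 3, this assay gives a limit and not a number: the limit of > 100000 nM in this assay, at which 1 of the 3 values shown sits.

The floors of the two new steps, an at least 1.1-fold higher number from compound 2 to compound 3 (0.04 log units; that floor lies within the scatter) and an at least 1.9-fold higher number from compound 1 to compound 3 (0.29 log units; that floor lies within the scatter), both lie within the scatter, so benzyl on the amide-type nitrogen cannot be ranked against pyridin-2-yl or 3-methoxyphenyl. Going by these compounds, what the position gains from this result is a third group, one with a six-membered aromatic ring of carbon only, and that exchange gives no sign of a stronger inhibitor, while the true size of each step remains unknown beyond its floor.

On these data alone, how far compound 3 lies past its limit remains open, and with it whether benzyl differs at all from the other two groups on this nitrogen. Also open, as far as these compounds go, is whether a longer chain such as 2-phenylethyl, or a group carrying an amine or a carboxylic acid, on the same amide-type nitrogen would move the number beyond the scatter in either direction.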